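The source may hold more compounds than are shown below. What is called first, only, known or untested is meant among the compounds shown, and "the series" means these compounds.

Compounds measured so far in a functional assay on CCRF-CEM cells (Homo sapiens) for cytotoxicity, read by sulforhodamine B assay, with a stated time of 24 h; a higher number here means a weaker inhibitor of growth, a lower number a stronger inhibitor of growth:
- compound 1, `COc1ccc(C(=O)/C=C/c2cc3ccccc3[nH]c2=O)cc1`: a limit, > 100000 nM
- compound 2, `O=C(/C=C/c1cc2ccccc2[nH]c1=O)c1ccc(O)cc1`: a limit, > 100000 nM

Compound 2 stands only at a limit of this assay. The step from compound 1 to compound 2, a step that the two limits leave unreadable from compound 1 to compound 2, is therefore unreadable, both ends sitting at the limit of > 100000 nM in this assay, at which 2 of the 2 values shown sit. Compound 3, `O=C(/C=C/c1cc2ccccc2[nH]c1=O)c1ccc(Cl)cc1`, differs from compound 2 by chloro in place of hydroxy on an aromatic carbon. Among the compounds with values here, no measured step reads on this change, so compound 3 is expected to remain at the limit, and the step of a number no higher from compound 2 to compound 3 (the limit leaves the size open) is an estimate without support. Compound 3 is estimated at 100000 nM, with a range from 20000 nM to 300000 nM.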

Compound 3, concentration for total growth inhibition: > 100000 nM
Compound 3: a limit, no number; the forecaster's own chance of this, stated with the estimate: 70%; the middle value sits exactly at the limit.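

Within the data shown here, compound 3, like compound 1 and compound 2, stands only at a limit, so no step among the three can be read: the limit of > 100000 nM in this assay, at which 3 of the 3 values shown sit. In this assay the compounds shown leave open whether any group at this place gives a readable value.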